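Cytotoxicity notes: from compound 2 to compound 3

This account rests on a few compounds, and the source may have more. Where it says the series, first, only, none or still open, it means among the compounds named here.

Compound 2 `Cn1cc(SCc2nnc(SCc3c(Cl)cccc3Cl)n2-c2c(Cl)cccc2Cl)c2ccccc21` carries a 2,6-dichlorophenyl on the saturated chain carbon bound to a sulfur. In a toxicity assay on HEK-293T cells (Homo sapiens) for cytotoxicity, read by CCK-8 assay, with a stated time of 48 h (a higher number here means that more compound is tolerated, a lower number that less compound is tolerated), compound 2 gives only a limit, > 100000 nM. Compound 1 `Cn1cc(SCc2nnc(SCc3ccccc3)n2-c2c(Cl)cccc2Cl)c2ccccc21`, with a phenyl in that place, also reaches only a limit in this assay, > 100000 nM. Within the data shown here, the step that the two limits leave unreadable from compound 1 to compound 2 therefore cannot be read, and the sole evidence is the limit of > 100000 nM in this assay, at which 2 of the 2 values shown sit. Compound 3 `Cn1cc(SCc2nnc(SCc3ccc(OC(F)(F)F)c(Cl)c3)n2-c2c(Cl)cccc2Cl)c2ccccc21` is not yet measured; the change is 3-chloro-4-(trifluoromethoxy)phenyl in place of 2,6-dichlorophenyl on a saturated chain carbon bound to a sulfur. Among the measured compounds shown here, no measured step bears on this change; the one step measured, a phenyl to a 2,6-dichlorophenyl, stayed at the limit at both ends. The expectation is that compound 3 also sits at the limit, so the estimated step is a step that the limit leaves unreadable from compound 2 to compound 3, nothing readable beyond the scatter. Compound 3 is therefore expected at 120000 nM, with a range from 40000 nM to 300000 nM.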

Compound 3, half-maximal cytotoxic concentration: 77700 nM
Beside the measured number, compound 3's estimate is 1.5-fold (0.19 log units) above it, within the range that was stated.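

Compound 3 is the only one of the three with a number rather than a limit in this assay, so 3-chloro-4-(trifluoromethoxy)phenyl on the saturated chain carbon bound to a sulfur brings the series into readable range. The readable steps are an at least 1.2-fold lower number from compound 2 to compound 3 (0.10 log units; that floor lies within the scatter) and an at least 1.2-fold lower number from compound 1 to compound 3 (0.10 log units; that floor lies within the scatter) at this position, and with both floors within the scatter, neither establishes a real change in tolerated concentration. The step between the other two compounds cannot be read, since both stay at a limit: the limit of > 100000 nM in this assay, at which 2 of the 3 values shown sit.

Which part of the 3-chloro-4-(trifluoromethoxy)phenyl group accounts for the number remains open. So does the response of this assay to an amine or a carboxylic acid at this place, or to a longer chain between the sulfur and the aromatic ring.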